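The source may report more compounds than this note shows. Statements on the series, on what has been measured and on what is new or still open speak of the compounds shown alone.

Compound 1 `COc1ccccc1S(=O)(=O)c1ccc(NC(=O)C(C)(O)C(F)(F)F)cc1`: 1600 nM
Compound 2 `Cc1cc(C(=O)c2ccccc2)ccc1NC(=O)C(C)(O)C(F)(F)F`: 5000 nM

In a functional assay (Cavia porcellus) with sulfonylurea receptors; K-ATP channels (Homo sapiens) as the target (a lower number here means a stronger inhibitor, a higher number a weaker inhibitor), compound 1 holds the lower of the two numbers, and compound 2 stands beyond the scatter above it. Compound 3 `CC(O)(C(=O)Nc1ccc(S(=O)(=O)c2ccccn2)cc1)C(F)(F)F` differs from compound 1 by pyridin-2-yl in place of 2-methoxyphenyl on a sulfonyl sulfur. Within the data shown here, no measured pair shows a change of this kind, so no step can be read off for it. With so little to go on, a small shift toward a weaker inhibitor, within or just beyond the scatter, seems the likeliest outcome. Compound 3 is therefore expected to give 2500 nM in this assay, with a range from 800 nM to 8000 nM. The expected step is a 1.6-fold higher number from compound 1 to compound 3 (0.19 log units; within the scatter).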

Compound 3, half-maximal inhibitory concentration: 600 nM
Beside the measured number, compound 3's estimate is 4.2-fold (0.62 log units) above it; the measured number lies below the stated range.
By their numbers in this assay, from the lowest: compound 3; then compound 1; then compound 2.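

The group on the sulfonyl sulfur clearly affects inhibition in this assay: pyridin-2-yl in place of 2-methoxyphenyl gives a 2.7-fold lower number from compound 1 to compound 3 (0.43 log units; beyond the scatter), a modest change. This position therefore accepts a ring holding a nitrogen atom, with fewer heavy atoms, without losing inhibition. Nothing available explains this gain. Among these compounds, the single swap removes the methoxy group and adds the ring nitrogen together, so the share of each stays open. As far as these compounds go, how an unsubstituted phenyl group or a small methyl group would compare on the same sulfur also remains unknown.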